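The source may hold more compounds than are shown below. What is called first, only, known or untested is meant among the compounds shown, and "the series" means these compounds.

compound 1 `O=C(CCc1ccc(COc2ccccc2)cc1)c1ncco1`: in an assay on isolated protein for inhibition of neutral cholesterol ester hydrolase 1 (Homo sapiens) (a higher number here means a weaker inhibitor, a lower number a stronger inhibitor), compound 1 gives > 100000 nM, a limit of the assay rather than a number.
compound 2 `O=C(CCc1ccc(-c2ccccc2)cc1)c1ncc(-c2cccc(-c3nnn[nH]3)n2)o1`: in this assay compound 2 gives > 100000 nM, likewise a limit and not a number.

Compound 2 therefore stands only at a limit in this assay, and the other value known for the series is a limit as well, since (the limit of > 100000 nM in this assay, at which 2 of the 2 values shown sit). Nothing in the measured pair resolves a step between them beyond the fact that both sit at the same limit.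

Compound 3 `O=C(CCc1ccc(COc2ccccc2)cc1)c1ncc(-c2cccc(-c3nnn[nH]3)n2)o1` is the next point. It differs from compound 2 by phenoxymethyl in place of phenyl on an aromatic carbon. With both measured compounds at the limit, no step beyond the scatter is expected, and compound 3 is expected to remain at or near the limit as well, so the step that the limit leaves unreadable from compound 2 to compound 3 is estimated as none beyond the scatter. For compound 3 the estimate is 150000 nM, with a range from 40000 nM to 600000 nM.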

Compound 3, half-maximal inhibitory concentration: > 100000 nM
Compound 3: a limit, no number; the forecaster's own chance of this, stated with the estimate: 85%; the middle value is on the limit's open side.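

In this assay compound 3 gives > 100000 nM, a limit and not a number. No step from compound 1 or compound 2 to compound 3 can be read: the limit of > 100000 nM in this assay, at which 3 of the 3 values shown sit.

The compounds shown leave open what separates these structures in this assay, as none has a measurable value.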